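This account rests on a few compounds, and the source may have more. Where it says the series, first, only, none or still open, it means among the compounds named here.

Compound 2 `CC1CCN(c2c(S(=O)(=O)c3ccc(Cl)cc3)cnc3cc(F)ccc23)CC1` gives 90% in an assay on isolated protein for displacement of a labelled ligand from metabotropic glutamate receptor 5 (Homo sapiens), with a stated time of 60 min, tested at 1 uM (a lower number here means less inhibition, a higher number more inhibition at the concentration tested (going by the name of the read-out)), and stands highest of the three measured compounds. Compound 3 `CC1CCN(c2c(S(=O)(=O)c3ccc(C#N)cc3)cnc3cc(F)ccc23)CC1` gives 83% in this assay; the two cores differ by chloro in place of cyano on an aromatic carbon, and the step of a number 7 percentage points lower from compound 2 to compound 3 (within the scatter) lies within the scatter. Compound 1 `CC1CCN(c2c(S(=O)(=O)c3ccc(C#N)cc3)cnc3cc(Cl)ccc23)CC1` gives 70% in this assay. The change from compound 3 to compound 1 is chloro in place of fluoro on an aromatic carbon, and it produced the step of a number 13 percentage points lower from compound 3 to compound 1 (beyond the scatter). Compound 4 `CC1CCN(c2c(S(=O)(=O)c3ccc(Cl)cc3)cnc3cc(Cl)ccc23)CC1`, not yet measured, differs from compound 2 by chloro in place of fluoro on an aromatic carbon, the same change at the same place, occurring twice among these compounds. Because compound 3 to compound 1 showed a number 13 percentage points lower from compound 3 to compound 1 (beyond the scatter), a comparable step is expected from compound 2 to compound 4, namely a number 11 percentage points lower from compound 2 to compound 4 (beyond the scatter). Compound 4 is therefore estimated at 79% in this assay, with a plausible range from 65% to 92%.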

Compound 4, a percentage reported as inhibition, at one concentration (the size of the read-out at that concentration, not a potency): 91%
Beside the measured number, compound 4's estimate is 12 percentage points below it, and the stated range covers the measured number.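

Chloro in place of fluoro gave a number 1 percentage points higher from compound 2 to compound 4 (within the scatter) in this assay, and the two occurrences of this change cannot be told apart: the same change on two cores in this assay, a number 13 percentage points lower (beyond the scatter) from compound 3 to compound 1 and a number 1 percentage points higher (within the scatter) from compound 2 to compound 4, 14 percentage points apart, within the scatter of two such steps. Chloro in place of cyano gave a number 21 percentage points higher from compound 1 to compound 4 (beyond the scatter), and its two occurrences also cannot be told apart: the same change on two cores in this assay, a number 7 percentage points lower (within the scatter) from compound 2 to compound 3 and a number 21 percentage points lower (beyond the scatter) from compound 4 to compound 1, 14 percentage points apart, within the scatter of two such steps. Neither change is thus shown to depend on the core, but this does not establish that either carries over with a fixed size, as each has one step within the scatter and one beyond it, and only two cores are compared.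

On these data alone, whether a methoxy group or an amine at either of these places would follow the same pattern remains open. Also open, as far as these compounds go, is how these single-concentration readings relate to potency.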